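The source may report more compounds than this note shows. Statements on the series, on what has been measured and on what is new or still open speak of the compounds shown alone.

Compound 1, `Nc1scc(CN2CCN(c3ccc(Cl)cc3F)CC2)c1C(=O)c1ccc(Cl)cc1`, gives -9.2% in a functional assay on CHO cells with adenosine receptor A1 (Homo sapiens) as the target, read by cAMP accumulation and immunoassay, with a stated time of 6 min, tested at 0.01 uM; on this read-out lower numbers stand for a stronger effect and higher numbers for a weaker effect at the one concentration tested.
Compound 2, `Nc1scc(CN2CCN(c3ccc(Cl)c(C(F)(F)F)c3)CC2)c1C(=O)c1ccc(Cl)cc1`, gives -2.5% in this assay.

Among these two numbers compound 2 stands at the higher one, yet the single measured step, a number 6.7 percentage points higher from compound 1 to compound 2 (within the scatter), lies within the scatter, so the two compounds cannot be told apart on this read-out. Compound 3, `Nc1scc(CN2CCN(c3cccc4ccccc34)CC2)c1C(=O)c1ccc(Cl)cc1`, has not yet been tested. It differs from compound 2 in one place: naphthalen-1-yl in place of 4-chloro-3-(trifluoromethyl)phenyl on an amine nitrogen in a ring. Among the compounds with values here, the only measured step touches the same position, the group on the ring nitrogen, and it brought no shift beyond the scatter. With no other evidence about this position, no step beyond the scatter is expected from compound 2 to compound 3, and the estimated step is a number 1.5 percentage points lower from compound 2 to compound 3 (within the scatter). Compound 3 is therefore expected to give about -4% in this assay, within a range from -19% to 11%.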

Compound 3, a percentage reported as activity, at one concentration (the size of the read-out at that concentration, not a potency): 8.7%
Estimate against measurement, compound 3: 12.7 percentage points below; the range from low to high includes it.
By their numbers in this assay, from the lowest: compounds 1 and 2 (each within the scatter of the next); then compound 3.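

The group on the ring nitrogen can shift this read-out after all: in this assay, the step is a number 11.2 percentage points higher from compound 2 to compound 3 (beyond the scatter) and, against the other halogenated phenyl, a number 17.9 percentage points higher from compound 1 to compound 3 (beyond the scatter). Higher numbers here stand for a weaker effect at the one concentration tested, so naphthalen-1-yl gives a weaker effect than either 4-chloro-3-(trifluoromethyl)phenyl or 4-chloro-2-fluorophenyl, two groups that could not be told apart from each other. Nothing shown gives a reason for this shift.

In both steps, a second aromatic ring enters while chlorine and fluorine leave, so the compounds shown cannot say which of these changes goes with the higher number. A plain phenyl or a naphthalen-2-yl on the same nitrogen would help separate them.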